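Swapping Hydroxy for Bromo on the Benzoyl Ring

The source may hold more compounds than are shown below. What is called first, only, known or untested is meant among the compounds shown, and "the series" means these compounds.

Measured so far in an assay for inhibition of Amine oxidase [flavin-containing] B (Bos taurus), read by fluorescence, with a stated time of 60 min; a lower number here means a stronger inhibitor, a higher number a weaker inhibitor:
compound 1 `O=C(NNc1nc2ccccc2nc1Cc1ccccc1)c1ccccc1`: 360000 nM
compound 2 `COc1ccc(C(=O)NNc2nc3ccccc3nc2Cc2ccccc2)cc1`: 920000 nM
compound 3 `O=C(NNc1nc2ccccc2nc1Cc1ccccc1)c1ccc(O)cc1`: 940000 nM

Compound 3 has the highest number of the three, yet compound 2 sits within the scatter of it; only compound 1 is clearly apart, as a 2.6-fold higher number from compound 1 to compound 3 (0.42 log units; beyond the scatter) shows. Compound 4 `O=C(NNc1nc2ccccc2nc1Cc1ccccc1)c1ccc(Br)cc1` differs from compound 3 by bromo in place of hydroxy on an aromatic carbon. For the measured compounds named here, no measured step brings in a halogen. The nearest guides are a 2.6-fold higher number from compound 1 to compound 3 (0.42 log units; beyond the scatter) and a 1.0-fold higher number from compound 2 to compound 3 (0.01 log units; within the scatter), which show that the hydroxy is not what makes compound 3 weak relative to compound 2, while dropping it back to hydrogen helped modestly. Compound 4 is therefore expected to give 400000 nM, between 150000 nM and 1200000 nM, an estimated step of a 2.4-fold lower number from compound 3 to compound 4 (0.37 log units; beyond the scatter).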

Compound 4, half-maximal inhibitory concentration: 980000 nM
Beside the measured number, compound 4's estimate is 2.5-fold (0.39 log units) below it, and the stated range covers the measured number.
By their numbers in this assay, from the lowest: compound 1; then compounds 2, 3 and 4 (each within the scatter of the next).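

Trading hydroxy for bromo removes a hydrogen-bond donor and acceptor from this position, yet the numbers do not separate (a 1.0-fold higher number from compound 3 to compound 4 (0.02 log units; within the scatter)), and bromo in place of methoxy gives the same picture (a 1.1-fold higher number from compound 2 to compound 4 (0.03 log units; within the scatter)). Against plain hydrogen, bromo stands clearly apart (a 2.7-fold higher number from compound 1 to compound 4 (0.43 log units; beyond the scatter)), so hydroxy, methoxy and bromo all read alike, and only hydrogen differs. Nothing available explains this sameness. On these data alone, whether an amine or a carboxylic acid at this position would join those three or match hydrogen remains open.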